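The compounds below may be only part of what the source reports. "The series", "measured", "known", "first", "only" and "open" are said of these compounds alone.

Of the compounds shown here, two have so far been tested in a functional assay on the whole organism for inhibition, with Scenedesmus acutus as the target, read by spectrophotometry, with a stated time of 48 h; a lower number here means a stronger inhibitor, a higher number a weaker inhibitor. Compound 1, `NC1=NC=NC2=NC(c3ccc(Cl)cc3F)NN12`, gives 100000 nM. Compound 2, `Nc1ncnc2nc(-c3ccc(Cl)cc3)nn12`, gives 100000 nM, level with compound 1 at the digits shown and within the usual scatter. Compound 3, `Nc1ncnc2nc(-c3ccc(Cl)cc3F)nn12`, has not yet been measured. It differs from compound 2 by fluoro in place of hydrogen on an aromatic carbon. Within the data shown here, no measured pair shows what this kind of change does here, so the expected step from compound 2 to compound 3 in this assay is no change at the digits printed from compound 2 to compound 3 (within the scatter), nothing beyond the scatter. Compound 3 is thus estimated at 100000 nM, with a range from 30000 nM to 100000 nM.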

Compound 3, half-maximal inhibitory concentration: 14100 nM
Compound 3: middle estimate off by 7.1-fold (0.85 log units), on the high side, and the stated range ends above it.
By their numbers in this assay, from the lowest: compound 3; then compounds 1 and 2 (each within the scatter of the next).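

In this assay, fluoro in place of hydrogen on an aromatic carbon, ortho to a large group and meta to a chloro group, gives a 7.1-fold lower number from compound 2 to compound 3 (0.85 log units; beyond the scatter) and so shows that this position is sensitive to a change of one fluorine atom. Among these compounds, no earlier measured pair showed what a change at this position does. Nothing available explains the step. The compounds shown leave open whether a chlorine atom, a methyl group or an amine at this position would give a similar step. They also leave open whether fluoro on another carbon of this ring would do the same.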